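Chloro Added to the Benzyl Arm of Compound 3

A few compounds are considered here, and "the series" means these few. Any claim that something is new, unique, unknown or untested is made for them only; others in the source may bear on it.

Measured compounds and their numbers:
compound 1, `COc1ccc(C2N=C(SCc3ccc(Cl)cc3)NC(C)=C2C(=O)Nc2ccc(F)cc2)cc1OC`, gives 31.3%
compound 2, `CC1=C(C(=O)Nc2ccc(F)cc2)C(c2ccc([N+](=O)[O-])cc2)N=C(SCc2ccccc2Cl)N1`, gives 18.5%
compound 3, `CC1=C(C(=O)Nc2ccc(Br)cc2)C(c2ccc(Cl)cc2Cl)N=C(SCc2ccccc2)N1`, gives 22.1%

All three numbers come from a functional assay on the whole organism (artery, strain albino) with Rattus norvegicus as the target, with a stated time of 300 min, at a dose of 10 mg/kg by the oral route; on this read-out lower numbers stand for less inhibition and higher numbers for more inhibition at the one dose given (going by the name of the read-out). Compound 3 holds the second highest of the three; its nearest neighbour is compound 2, whose number is lower, and the furthest is compound 1, whose number is higher, yet both gaps lie within the usual scatter of repeated measurements, so the three compounds cannot be told apart on these numbers alone. Among the compounds with values here, none of the three pairs differs in only one place, so no single step between measured compounds is available to lean on.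

Compound 4, `CC1=C(C(=O)Nc2ccc(Br)cc2)C(c2ccc(Cl)cc2Cl)N=C(SCc2cccc(Cl)c2)N1`, is the next compound, not yet measured. It differs from compound 3 in one place: chloro in place of hydrogen on an aromatic carbon. The benzyl group on the sulfur of compound 3 thus becomes a 3-chlorobenzyl group. Compounds 1 and 2 carry a chlorine on the same ring, though in other places, and their numbers in this assay sit within the scatter of compound 3. The expected step of a number 1.9 percentage points higher from compound 3 to compound 4 (within the scatter) is therefore small, in no clear direction, and not beyond the scatter. Compound 4 is estimated to give 24%, between 10% and 40%.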

Compound 4, a percentage reported as inhibition, in the whole organism at one dose (the size of the read-out at that dose, not a potency): 18.5%
Estimate against measurement, compound 4: 5.5 percentage points above; the range from low to high includes it.
By their numbers in this assay, from the lowest: compounds 2, 4, 3 and 1 (each within the scatter of the next, the first and the last beyond it).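

Within the data shown here, this is the first step where only one place changes, so it isolates the effect of a single chloro on the benzyl arm. In this assay, the change to a 3-chlorobenzyl group gives a number 3.6 percentage points lower from compound 3 to compound 4 (within the scatter), so this chloro on this aromatic carbon produces no difference that can be told apart from the ordinary spread of repeated measurements, and the benzyl ring can carry it without a clear gain or loss in the read-out at this one dose. Nothing at hand offers an explanation for where the number of compound 4 falls.

Chlorine on other carbons of this ring appears only in compound 1 and compound 2, which also differ from compound 3 elsewhere, so the data cannot say whether moving the chloro around the ring would matter. On these data alone, it also remains open whether a different group on this same aromatic carbon, such as a methoxy group, an amine or a carboxylic acid, would take the number beyond the scatter, or whether this carbon gives little change whatever it carries.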